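Swapping the Aryl Group on a Four-Membered Ring

The source may report more compounds than this note shows. Statements on the series, on what has been measured and on what is new or still open speak of the compounds shown alone.

Compound 1 `COC(=O)/C(=C/c1ccccc1)CN1C(=O)[C@@H](OC)[C@H]1c1ccc(F)cc1`: 15600 nM
Compound 2 `CO[C@@H]1C(=O)N(C/C(C#N)=C/c2ccccc2)[C@@H]1c1ccc(Cl)cc1Cl`: 31900 nM

Both compounds were tested in a functional assay on MCF7 cells (Homo sapiens) for antiproliferative activity, read by MTT assay, with a stated time of 48 h (a lower number here means a stronger inhibitor, a higher number a weaker inhibitor), and compound 1 holds the lower of the two numbers. Compound 2 reads higher, by a gap just beyond the usual scatter. The two differ in more than one place, so their gap says nothing about a single group.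

Compound 3 `COC(=O)/C(=C/c1ccccc1)CN1C(=O)[C@@H](OC)[C@H]1c1cccc([N+](=O)[O-])c1` has not yet been measured. It keeps the rest of compound 1 and changes one group on a saturated ring carbon of the four-membered non-aromatic ring, next to the ring nitrogen. The change 3-nitrophenyl in place of 4-fluorophenyl on a saturated ring carbon puts 3-nitrophenyl in place of 4-fluorophenyl.

Among the measured compounds shown here, no measured pair shows this exchange alone, so the expectation stays close to compound 1 at 15600 nM as its only anchor. No step beyond the scatter is expected in this assay and any drift is expected toward a slightly higher number. The estimated change is a 1.3-fold higher number from compound 1 to compound 3 (0.11 log units; within the scatter) as a middle figure. For compound 3 the expected value is 20000 nM with an estimated range from 7000 nM to 55000 nM when it is measured.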

Compound 3, half-maximal inhibitory concentration: 15000 nM
The estimate for compound 3 lay 1.3-fold (0.12 log units) above the measured number; the range from low to high includes it.
By their numbers in this assay, from the lowest: compounds 3 and 1 (each within the scatter of the next); then compound 2.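

Across this assay, putting 3-nitrophenyl in place of 4-fluorophenyl on this saturated ring carbon gives a 1.0-fold lower number from compound 1 to compound 3 (0.02 log units; within the scatter), the first comparison here in which only one group changes. The assay does not separate the two aryl groups at this position, even though 3-nitrophenyl has more heavy atoms, carries hydrogen-bond acceptors that 4-fluorophenyl lacks, and has its substituent at a different ring position. No independent measurement is available to explain why the two compounds read alike.

This single exchange cannot show whether the substituent itself or its place on the phenyl ring matters, and a 4-nitrophenyl or 3-fluorophenyl group on the same carbon would pull those two changes apart. It also leaves open whether the position would stay as undiscriminating with a phenyl ring bearing an amine or a carboxylic acid, or with a simple methyl group in place of the aryl ring, and whether the same holds when the rest of the core of compound 1 changes.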